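Swapping a Nitro Group for a Hydroxymethyl Group

The source may report more compounds than this note shows. Statements on the series, on what has been measured and on what is new or still open speak of the compounds shown alone.

Measured compounds:
compound 1, `COc1ccc(/C=C\C(=O)O)c(OCc2cn(-c3ccccc3C(=O)N3CCC(O)C3)nn2)c1CC=C(C)C`: 13400 nM
compound 2, `COc1ccc(/C=C\C(=O)O)c(OCc2cn(-c3cccc([N+](=O)[O-])c3)nn2)c1CC=C(C)C`: 15400 nM

Both compounds were tested in a functional assay on T47D cells (Homo sapiens) for cytotoxicity, read by MTT assay, with a stated time of 24 h; on this read-out higher numbers stand for weaker inhibition and lower numbers for stronger inhibition. Compound 2 carries the highest of the two numbers, but its gap to compound 1 lies within the usual scatter of repeated measurements, so the two cannot be told apart on this read-out. Compound 3, `COc1ccc(/C=C\C(=O)O)c(OCc2cn(-c3ccc(CO)cc3)nn2)c1CC=C(C)C`, has not yet been measured. It differs from compound 2 in a single place: 4-(hydroxymethyl)phenyl in place of 3-nitrophenyl on an aromatic nitrogen. Among the compounds with values here, no step between measured compounds covers a change of this kind, and the two values already known sit close together. Compound 3 is therefore expected to stay near compound 2, with a step of a 1.1-fold lower number from compound 2 to compound 3 (0.04 log units; within the scatter) that is estimated to be no larger than the scatter, in either direction. The estimate for compound 3 in this assay is 14000 nM, with a range from 5000 nM to 40000 nM.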

Compound 3, half-maximal inhibitory concentration: 40000 nM
Compound 3: the middle estimate sits 2.9-fold (0.46 log units) below what was measured, and the stated range covers the measured number.
By their numbers in this assay, from the lowest: compounds 1 and 2 (each within the scatter of the next); then compound 3.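

In this assay the exchange of 3-nitrophenyl for 4-(hydroxymethyl)phenyl on the aromatic nitrogen gives a 2.6-fold higher number from compound 2 to compound 3 (0.41 log units; beyond the scatter) and so means weaker inhibition. This is the only step shown for this position, and it shows that the group carried there can move the read-out beyond the scatter, though only modestly. Nothing measured here gives a reason for this step.

The exchange alters both the group on the phenyl ring and its place on that ring, so the compounds shown cannot separate these two changes, and 3-(hydroxymethyl)phenyl would be the direct test. From the compounds shown here alone, it also remains open how a phenyl ring carrying an amine or a carboxylic acid would compare with compound 2 and compound 3 at this position.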